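The source may hold more compounds than are shown below. What is called first, only, known or untested is meant among the compounds shown, and "the series" means these compounds.

Measured compounds and their numbers:
compound 1, `OC[C@H]1O[C@@H](n2cnc3c(SC4CCCCC4)ncnc32)[C@H](O)[C@@H]1O`, gives 6310 nM in an assay on isolated protein for binding affinity to Equilibrative nucleoside transporter 1 (Homo sapiens); a higher number here means a weaker inhibitor, a lower number a stronger inhibitor;
compound 2, `OC[C@H]1O[C@@H](n2cnc3c(Sc4ccccc4)ncnc32)[C@H](O)[C@@H]1O`, gives 91200 nM in this assay;
compound 3, `OC[C@H]1O[C@@H](n2cnc3c(CSc4ccccc4Cl)ncnc32)[C@H](O)[C@@H]1O`, gives 1780 nM in this assay.

Compound 3 has the lowest number of the three in this assay, so it is the strongest inhibitor measured here. Of the two steps leading to it, a 3.5-fold lower number from compound 1 to compound 3 (0.55 log units; beyond the scatter) is modest, while a 51-fold lower number from compound 2 to compound 3 (1.71 log units; beyond the scatter) is large. The third step, a 14-fold higher number from compound 1 to compound 2 (1.16 log units; beyond the scatter), shows that swapping the group on a sulfur can move the number a great deal.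

Compound 4, `OC[C@H]1O[C@@H](n2cnc3c(CSc4cccc(I)c4)ncnc32)[C@H](O)[C@@H]1O`, differs from compound 3 in one place: 3-iodophenyl in place of 2-chlorophenyl on a sulfur. Among the compounds with values here, no measured step compares two halogenated phenyl rings on a sulfur; the only change of a group on a sulfur, from compound 1 to compound 2, traded a saturated ring for an aromatic one, which is a different kind of change. With nothing closer to lean on, no step beyond the scatter is expected in this assay, but the range must be wide. Compound 4 is therefore estimated to give 1500 nM, between 400 nM and 6000 nM. That amounts to an expected step of a 1.2-fold lower number from compound 3 to compound 4 (0.07 log units; within the scatter).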

Compound 4, half-maximal inhibitory concentration: 245 nM
Compound 4: the middle estimate sits 6.1-fold (0.79 log units) above what was measured; measured number outside the range, below it.
By their numbers in this assay, from the lowest: compound 4; then compound 3; then compound 1; then compound 2.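

Two halogenated phenyl rings on this sulfur are not interchangeable: a 7.3-fold lower number from compound 3 to compound 4 (0.86 log units; beyond the scatter) in this assay, although the two groups match in heavy-atom count and in their single aromatic ring of carbon. The 3-iodophenyl group also leaves compound 4 well clear of the two compounds with a sulfur-linked ring and no added carbon, with a 370-fold lower number from compound 2 to compound 4 (2.57 log units; beyond the scatter) and a 26-fold lower number from compound 1 to compound 4 (1.41 log units; beyond the scatter), which makes compound 4 the strongest inhibitor of the four. No measurement offered here explains why this swap lowers the number.

The halogen and its place on the ring change together between compound 3 and compound 4, so the compounds shown cannot say which of the two matters. Also open, on these data alone, is how a phenyl ring carrying bromine, an amine or a carboxylic acid would behave on this sulfur.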